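Amide-to-ester swap on the hydroxy core

The source may report more compounds than this note shows. Statements on the series, on what has been measured and on what is new or still open speak of the compounds shown alone.

Measured so far:
compound 1 `CCn1c(C(=O)N(CCC#N)CCC#N)ccc1C(CC)(CC)c1ccc(OCC(=O)C(C)(C)C)c(C)c1`: 870 nM
compound 2 `C#CC(C)OC(=O)c1ccc(C(CC)(CC)c2ccc(OCC(=O)C(C)(C)C)c(C)c2)n1CC`: 210 nM
compound 3 `CCn1c(C(=O)N(CCC#N)CCC#N)ccc1C(CC)(CC)c1ccc(OCC(O)C(C)(C)C)c(C)c1`: 97 nM

In an assay on HL-60 cells for agonist activity at vitamin D3 receptor (Homo sapiens), read by microscopy, with a stated time of 96 h (on this read-out higher numbers stand for an effect only at larger amounts of compound and lower numbers for an effect already at smaller amounts), compound 1 gives 870 nM. The change a group of 5 heavy atoms (4 carbon, 1 oxygen; no ring) in place of a group of 9 heavy atoms (6 carbon, 3 nitrogen; no ring), on a carbonyl carbon gave a 4.1-fold lower number from compound 1 to compound 2 (0.62 log units; beyond the scatter). Separately, 1-hydroxy-2,2-dimethylpropyl in place of (tert-butyl)carbonyl on a saturated chain carbon bound to an oxygen on an aromatic ring gave a 9.0-fold lower number from compound 1 to compound 3 (0.95 log units; beyond the scatter), and compound 3 holds the lowest number of the three in this assay.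

Compound 4 `C#CC(C)OC(=O)c1ccc(C(CC)(CC)c2ccc(OCC(O)C(C)(C)C)c(C)c2)n1CC` has not been measured. It differs from compound 3 by a group of 5 heavy atoms (4 carbon, 1 oxygen; no ring) in place of a group of 9 heavy atoms (6 carbon, 3 nitrogen; no ring), on a carbonyl carbon, the same change, at the same place, that made a 4.1-fold lower number from compound 1 to compound 2 (0.62 log units; beyond the scatter). The two cores differ by 1-hydroxy-2,2-dimethylpropyl in place of (tert-butyl)carbonyl on a saturated chain carbon bound to an oxygen on an aromatic ring.

For compound 4 in this assay a step of about a 3.5-fold lower number from compound 3 to compound 4 (0.54 log units; beyond the scatter) is expected, since the same change gave a 4.1-fold lower number from compound 1 to compound 2 (0.62 log units; beyond the scatter) and compound 3 starts from 97 nM. The estimate for compound 4 is 28 nM, expected between 9 nM and 90 nM.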

Compound 4, half-maximal effective concentration: 200 nM
Compound 4: middle estimate off by 7.1-fold (0.85 log units), on the low side; the measured number lies above the stated range.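

In this assay, (1-methylprop-2-yn-1-yl)oxy on the carbonyl carbon gives a 2.1-fold higher number from compound 3 to compound 4 (0.31 log units; beyond the scatter), so this change does not carry from one core to the other in either size or direction: the same change on two cores in this assay, a 4.1-fold lower number (0.62 log units; beyond the scatter) from compound 1 to compound 2 and a 2.1-fold higher number (0.31 log units; beyond the scatter) from compound 3 to compound 4, 8.5-fold (0.93 log units) apart, beyond the scatter of two such steps. The other change, 1-hydroxy-2,2-dimethylpropyl in place of (tert-butyl)carbonyl, does not carry over either, giving a 1.1-fold lower number from compound 2 to compound 4 (0.02 log units; within the scatter) on the core of compound 2: the same change on two cores in this assay, a 9.0-fold lower number (0.95 log units; beyond the scatter) from compound 1 to compound 3 and a 1.1-fold lower number (0.02 log units; within the scatter) from compound 2 to compound 4, 8.5-fold (0.93 log units) apart, beyond the scatter of two such steps. The two changes are therefore not additive across these four compounds, but a single set of four does not show why, or whether the same holds for other groups on the carbonyl carbon.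

As far as these compounds go, it remains open whether a methyl ester, a carboxylic acid or a simple dimethyl amide on the carbonyl carbon would behave like compound 2 or like compound 4 on each core.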